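Swapping the amide substituent on compound 2 for a pyridinylmethyl group

The source may hold more compounds than are shown below. What is called first, only, known or untested is meant among the compounds shown, and "the series" means these compounds.

Compound 2 `CC(C)CNC(=O)Cn1sc2ccccc2c1=O` was tested in an assay on isolated protein for inhibition of histone acetyltransferase KAT2B (Homo sapiens), read by fluorescence, with a stated time of 10 min, tested at 50 uM (on this read-out lower numbers stand for less inhibition and higher numbers for more inhibition at the one concentration tested (going by the name of the read-out)), and gave 95%. Among the three measured compounds it stands close to compound 1 `CCOC(=O)Cn1sc2nc(C)cc(C)c2c1=O`, which in this assay gave 97%, the two lying within the scatter of each other, and far above compound 3 `CCNC(=O)OCCn1sc2nc(C)cc(C)c2c1=O`, which in this assay gave 14%. Compound 4 `O=C(Cn1sc2ccccc2c1=O)NCc1ccccn1` has not been measured yet. It differs from compound 2 in one place: pyridin-2-yl in place of isopropyl on a saturated chain carbon bound to an amide-type nitrogen. The amide-linked core that carries the high reading of compound 2 is kept, so no step beyond the scatter is expected in this assay, in either direction. Compound 4 is therefore expected to give about 92%, with a range from 70% to 100%, a step of a number 3 percentage points lower from compound 2 to compound 4 (within the scatter) being the estimate.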

Compound 4, a percentage reported as inhibition, at one concentration (the size of the read-out at that concentration, not a potency): 91%
Estimate against measurement, compound 4: 1 percentage points above; the range from low to high includes it.
By their numbers in this assay, from the lowest: compound 3; then compounds 4, 2 and 1 (each within the scatter of the next).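

In this assay, within the data shown here, the exchange of isopropyl for pyridin-2-yl on a saturated chain carbon bound to an amide-type nitrogen gives a number 4 percentage points lower from compound 2 to compound 4 (within the scatter) as the only step read at this position. The high reading of compound 2 therefore survives the arrival of a six-membered aromatic ring with one hetero atom at this place, at the one concentration tested. Nothing available bears on why the reading holds here. As far as these compounds go, whether a primary amine, a carboxylic acid or a longer chain at this place would keep the reading stays open, as does how compound 2 and compound 4 would compare at lower concentrations.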